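A few compounds are considered here, and "the series" means these few. Any claim that something is new, unique, unknown or untested is made for them only; others in the source may bear on it.

Measured so far:
- compound 1 `CC(C)(C)Cn1cc2c(Cl)nc(NC(=O)c3ccccc3)nc2n1`: 11000 nM
- compound 2 `CC(C)(C)Cn1cc2c(Cl)nc(N)nc2n1`: 12000 nM

Both numbers come from an assay on CHO cells for displacement of a labelled ligand from adenosine receptor A1 (Homo sapiens), read by scintillation counting, with a stated time of 3 h; a lower number here means a stronger inhibitor, a higher number a weaker inhibitor. Compound 2 stands at the highest of the two numbers, but its nearest neighbour is compound 1, and the step of a 1.1-fold higher number from compound 1 to compound 2 (0.04 log units; within the scatter) lies within the scatter, so the two compounds cannot be told apart on these data.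

Compound 3 `Cn1cc2c(Cl)nc(N)nc2n1` has not yet been measured. It differs from compound 2 in one place: hydrogen in place of tert-butyl on a saturated chain carbon bound to an aromatic nitrogen. Going by the values given here, the only measured step, a 1.1-fold higher number from compound 1 to compound 2 (0.04 log units; within the scatter), concerns a different place, the nitrogen that carries the benzoyl group in compound 1, and it changed the number by less than the scatter. Among the compounds with values here, no measured step touches the neopentyl chain, so nothing here tells how much the tert-butyl part of that chain contributes. Given that, the expectation for compound 3 is a step of about a 1.3-fold higher number from compound 2 to compound 3 (0.12 log units; within the scatter) in this assay, in the direction of a weaker inhibitor, with wide uncertainty. The estimate for compound 3 is therefore 16000 nM, expected to fall between 5000 nM and 50000 nM.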

Compound 3, inhibition constant: 29700 nM
For compound 3 the middle estimate is 1.9-fold (0.27 log units) below the measured one, within the range that was stated.
By their numbers in this assay, from the lowest: compounds 1 and 2 (each within the scatter of the next); then compound 3.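

Going by these compounds alone, the earlier pair showed only that removing the benzoyl group from the nitrogen gave no difference that could be read, so this is the first change here that exceeds the scatter. In this assay, cutting neopentyl to methyl, which removes a tert-butyl group of four carbons from a saturated chain carbon bound to an aromatic nitrogen, gives a 2.5-fold higher number from compound 2 to compound 3 (0.39 log units; beyond the scatter) and so a weaker inhibitor. The step is modest, but it shows that this place on the shared core is not indifferent to what it carries, although no measurement at hand explains the loss.

Among the compounds shown, only neopentyl and methyl stand at this place, so it remains open whether the number changes gradually along a series such as ethyl, propyl and longer chains, or depends on the branched tert-butyl shape itself. Also open, going by these compounds, is how a benzyl group, an amine or a carboxylic acid carried on this chain would compare, and whether the same step would appear with the benzoyl group on the nitrogen.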